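Replacing methoxy with trifluoromethyl on compound 2

This account rests on a few compounds, and the source may have more. Where it says the series, first, only, none or still open, it means among the compounds named here.

Compound 1 `Cc1nc(C)n(CC(=O)N2CCN(c3sc(C(F)(F)F)nc3-c3cnc(OC4CCC4)nc3)C[C@H]2C)n1`: 51 mL.min-1.g-1
Compound 2 `COc1ccc(-c2nc(C(F)(F)F)sc2N2CCN(C(=O)Cn3nc(C)nc3C)[C@H](C)C2)cn1`: < 10 mL.min-1.g-1

In a toxicity assay on microsomes from liver (Homo sapiens) for metabolic stability, read by LC-MS, using NADPH, tested at 1 uM (a higher number here means faster removal of the compound, a lower number slower removal), compound 2 gives < 10 mL.min-1.g-1, which is a limit of the assay and not a number. Compound 3 `Cc1nc(C)n(CC(=O)N2CCN(c3sc(C(F)(F)F)nc3-c3ccc(C(F)(F)F)nc3)C[C@H]2C)n1` differs from it by trifluoromethyl in place of methoxy on an aromatic carbon. Among the compounds with values here, only one measured step offers a guide, an at least 5.1-fold lower number from compound 1 to compound 2 (0.70 log units; beyond the scatter), and it lies beyond the scatter. That step swapped a different pair of groups, so it bears only loosely on this change. A modest rise is expected, estimated as an at least 1.3-fold higher number from compound 2 to compound 3 (0.11 log units; that floor lies within the scatter). For compound 3 the estimate is 13 mL.min-1.g-1, with an expected range of 5 mL.min-1.g-1 to 32 mL.min-1.g-1.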

Compound 3, intrinsic clearance in microsomes: < 10 mL.min-1.g-1
Compound 3: only a limit was reported; the forecaster's own chance of this, stated with the estimate: 35%; at least 1.3-fold (0.11 log units) between middle value and limit.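

In this assay compound 3 gives < 10 mL.min-1.g-1, which is a limit of the assay and not a number. Trifluoromethyl on the pyridine ring therefore also gives a reading at the limit, as methoxy did, and the change from the cyclobutyloxy compound gives an at least 5.1-fold lower number from compound 1 to compound 3 (0.70 log units; beyond the scatter). Which of the two groups is removed more slowly cannot be read, and the step between them stays unreadable: the limit of < 10 mL.min-1.g-1 in this assay, at which 2 of the 3 values shown sit.

On these data alone, how far each compound lies under the limit remains open. So does whether an amine or a longer chain such as ethoxy, in this same place, would keep the reading there.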